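The source may hold more compounds than are shown below. What is called first, only, known or untested is meant among the compounds shown, and "the series" means these compounds.

Compound 2, with the structure `O/N=C(\CCN1CCN(c2ccccn2)CC1)c1ccccc1Cl`, was tested in a functional assay on HEK293 cells with D(4) dopamine receptor (Homo sapiens) as the target, read by FLIPR (a higher number here means that more compound is needed for the effect, a lower number that less compound is needed), and gave 24 nM. Among the two compounds measured, compound 2 holds the higher of the two numbers, but its nearest neighbour, compound 1 with the structure `O/N=C(/CCN1CCN(c2ccccn2)CC1)c1ccccc1`, gives 21.7 nM in this assay, and that gap lies within the scatter; the two values show no difference that can be trusted.

Compound 3, drawn as `O/N=C(/CCN1CCN(c2ccccn2)CC1)c1ccccc1Cl`, has not yet been measured. It differs from compound 2 as follows: the two compounds have the same atoms and bonds and differ only in configuration as drawn: 1 of 1 stereo elements differ; a double bond is drawn E in compound 2 and Z in compound 3. Among the measured compounds shown here, no step between measured compounds covers this kind of change on its own; compound 1 and compound 2 differ both in this configuration and in the chlorine on the ring, so what they show cannot be assigned to either.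

For that reason only a small step is expected from compound 2 to compound 3 in this assay, with a 1.0-fold higher number from compound 2 to compound 3 (0.02 log units; within the scatter), in no firm direction, and probably not beyond the scatter. Compound 3 is therefore estimated at 25 nM, within a range from 8 nM to 80 nM.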

Compound 3, half-maximal effective concentration: 25 nM
Beside the measured number, compound 3's estimate shows no gap at the digits printed; measured number inside the range.
By their numbers in this assay, from the lowest: compounds 1, 2 and 3 (each within the scatter of the next).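

The earlier pair mixed two changes, and compounds 2 and 3 separate one of them: the fact that compounds 2 and 3 differ only in the configuration as drawn. In this assay, turning the double bond from E to Z gives a 1.0-fold higher number from compound 2 to compound 3 (0.02 log units; within the scatter), so with the chlorine in place, this change of configuration does not move the number beyond the scatter. With the double bond drawn the same way, chloro in place of hydrogen on an aromatic carbon gives a 1.2-fold higher number from compound 1 to compound 3 (0.06 log units; within the scatter), so this change also stays within the scatter, and neither of the two changes mixed in the earlier pair shows a difference that can be trusted.

The compounds shown leave open whether the double-bond configuration would matter as little with hydrogen in place of the chlorine, and whether a bromine, a methoxy group or a trifluoromethyl group on that aromatic carbon would keep the number as close to those of compounds 1, 2 and 3. They also leave open what a longer chain between the double bond and the shared core would do in this assay.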